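This account rests on a few compounds, and the source may have more. Where it says the series, first, only, none or still open, it means among the compounds named here.

Compound 1 `O=C1NCCN1c1ccc(S(=O)(=O)Nc2ccc(F)cc2)cc1`: 690 nM
Compound 2 `Cc1ccc(NS(=O)(=O)c2ccc(N3CCNC3=O)cc2)cc1C`: 230 nM
Compound 3 `Cc1ccc(NS(=O)(=O)c2ccc(N3CCNC3=O)cc2)c(C)c1`: 230 nM

In a functional assay on MCF7 cells (Homo sapiens) for antiproliferative activity, read by sulforhodamine B assay, with a stated time of 48 h (a higher number here means a weaker inhibitor, a lower number a stronger inhibitor), compound 1 gives 690 nM, the highest of the three numbers, so among these three it is the weakest inhibitor, and both other compounds lie beyond the scatter from it. Compound 4 `CCCCCCOc1ccc(NS(=O)(=O)c2ccc(N3CCNC3=O)cc2)cc1` differs from compound 1 in one place: hexyloxy in place of fluoro on an aromatic carbon. For the measured compounds named here, no measured step exchanges fluoro for hexyloxy, so the expectation rests on neighbours. The two steps that alter the same ring, a 3.0-fold lower number from compound 1 to compound 2 (0.48 log units; beyond the scatter) and a 3.0-fold lower number from compound 1 to compound 3 (0.48 log units; beyond the scatter), each replaced the 4-fluorophenyl on the sulfonamide nitrogen with a dimethylphenyl and each lowered the number modestly; the step of no change at the digits printed from compound 2 to compound 3 (within the scatter) shows that where the methyls sit made no difference. Taken together, leaving fluoro behind has so far given a modest gain, and a similar modest gain, with wide uncertainty, is expected for the longer hexyloxy group. Compound 4 is therefore estimated at 300 nM, with a range from 100 nM to 1200 nM. That estimate amounts to the expected step of a 2.3-fold lower number from compound 1 to compound 4 (0.36 log units; beyond the scatter).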

Compound 4, half-maximal inhibitory concentration: > 1000 nM
Compound 4: no number, only a limit (the forecaster's own chance of this, stated with the estimate: 5%); middle value at least 3.3-fold (0.52 log units) away from the limit.
By their numbers in this assay, from the lowest: compounds 2 and 3 (each within the scatter of the next); then compound 1. At a limit, above all of these: compound 4.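

In this assay the exchange of fluoro for hexyloxy gives an at least 1.4-fold higher number from compound 1 to compound 4 (0.16 log units; that floor lies within the scatter) on this aromatic carbon, para to a large group. Unlike the dimethylphenyl changes, this one brings no lower number, so leaving fluoro behind does not by itself give a gain, though the floor of the step alone does not establish a real loss. For compound 4 the result is a limit and not a number, so the full size of the step cannot be read, because only this is reported: the limit of > 1000 nM in this assay, at which 1 of the 4 values shown sits.

As far as these compounds go, whether a shorter chain such as methoxy or ethoxy on this carbon would lower the number or raise it stays open. So does the outcome with an amine or a carboxylic acid there.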